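This account rests on a few compounds, and the source may have more. Where it says the series, first, only, none or still open, it means among the compounds named here.

Compound 1, `Cc1cccc2c1nc(-c1c(F)cccc1F)n2Cc1c(F)cccc1F`: in a toxicity assay on CCRF-CEM cells (Homo sapiens) for cytotoxicity (a higher number here means that more compound is tolerated, a lower number that less compound is tolerated), compound 1 gives > 100 uM, a limit of the assay rather than a number.
Compound 2, `N#Cc1cccc2c1nc(-c1c(F)cccc1F)n2Cc1c(F)cccc1F`: in this assay compound 2 gives 26.7 uM.

Compound 2 therefore holds the only number shown, the other result being a limit. Among the compounds with values here, the single measured step is an at least 3.7-fold lower number from compound 1 to compound 2 (0.57 log units; beyond the scatter), which rests on the limit (the limit of > 100 uM in this assay, at which 1 of the 2 values shown sits). The unmeasured compound 3, `CC(=O)NCc1cccc2c1nc(-c1c(F)cccc1F)n2Cc1c(F)cccc1F`, differs from compound 2 by acetamidomethyl in place of cyano on an aromatic carbon. Within the data shown here, no measured step exchanges cyano for acetamidomethyl, so that one step gives only a loose guide. For compound 3 a modest rise is expected, a 2.1-fold higher number from compound 2 to compound 3 (0.31 log units; beyond the scatter). Compound 3 is thus estimated at 55 uM, between 15 uM and 150 uM.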

Compound 3, half-maximal toxic concentration: 20.8 uM
Compound 3: the middle estimate sits 2.6-fold (0.42 log units) above what was measured; the range from low to high includes it.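

In this assay, exchanging cyano for acetamidomethyl on this aromatic carbon barely registers: a 1.3-fold lower number from compound 2 to compound 3 (0.11 log units; within the scatter). Two quite different groups therefore give results that cannot be told apart here, and the second also stands clear of methyl: an at least 4.8-fold lower number from compound 1 to compound 3 (0.68 log units; beyond the scatter). The result for compound 1 is a limit rather than a number, so this last step gives only a minimum size: the limit of > 100 uM in this assay, at which 1 of the 3 values shown sits.

From the compounds shown here alone, how an amine, a carboxylic acid or a longer alkyl chain on this carbon would fare remains open. So does whether methyl is the exception among groups at this position.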